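Moving the chlorine on the aryl group of compound 1

The source may report more compounds than this note shows. Statements on the series, on what has been measured and on what is new or still open speak of the compounds shown alone.

Compound 1 `Clc1cccc(-c2nc(N3CCCCC3)c3nc[nH]c3n2)c1` is read in an assay on cells for displacement of a labelled ligand from adenosine receptor A1 (Homo sapiens), read by scintillation counting and radioligand binding, with a stated time of 60 min, tested at 10 uM; on this read-out lower numbers stand for less inhibition and higher numbers for more inhibition at the one concentration tested (going by the name of the read-out). In this assay compound 1 gives > 80%, which is a limit of the assay rather than a number. Compound 2 `CN1CCN(c2nc(-c3cccc(Cl)c3)nc3[nH]cnc23)CC1` likewise gives > 80%, again a limit. Compound 3 `Cn1cnc2c(N3CCCCC3)nc(-c3cccc(Cl)c3)nc21` gives 22.4%. The step from 4-methylpiperazin-1-yl in place of piperidin-1-yl is a step that the two limits leave unreadable from compound 1 to compound 2; the methyl in place of hydrogen on the aromatic nitrogen gives a number at least 57.6 percentage points lower from compound 1 to compound 3 (beyond the scatter). Compound 1 is therefore placed only by a limit, a point made by the limit of > 80% in this assay, at which 2 of the 3 values shown sit.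

Compound 4 `Clc1ccc(-c2nc(N3CCCCC3)c3nc[nH]c3n2)cc1` has not yet been measured. It differs from compound 1 as follows: 4-chlorophenyl in place of 3-chlorophenyl on an aromatic carbon. Among the compounds with values here, neither measured step touches the chlorophenyl group; both concern the other positions on the shared core, so no measured step bears directly on this change. Compound 1 is at the limit, so the step to compound 4 can only hold or fall. The step expected is a number at least 20 percentage points lower from compound 1 to compound 4 (beyond the scatter), a moderate drop as the estimate. Compound 4 is expected at 60%, with a range from 30% to 85%, and a fair chance that the assay again reports only a limit.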

Compound 4, a percentage reported as inhibition, at one concentration (the size of the read-out at that concentration, not a potency): > 80%
Compound 4: only a limit was reported (the forecaster's own chance of this, stated with the estimate: 30%); middle value at least 20 percentage points from the limit.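

In this assay compound 4 gives > 80% as a limit of the assay and not a number. Compound 1 also stands at a limit, so no step can be read from compound 1 to compound 4: the limit of > 80% in this assay, at which 3 of the 4 values shown sit.

On these data alone, how far compound 1, compound 2 and compound 4 differ in this read-out stays open.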